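A Methoxy in Place of Fluoro: Tolerated Concentration Expected Unchanged

This account rests on a few compounds, and the source may have more. Where it says the series, first, only, none or still open, it means among the compounds named here.

Measured so far in an ADME assay on HEL cells (Homo sapiens) for cytotoxicity; a higher number here means that more compound is tolerated, a lower number that less compound is tolerated:
compound 1, `O=C(COc1cccc2ccccc12)N/N=C/c1ccccc1`, 100 ug/mL
compound 2, `O=C(COc1cccc2ccccc12)N/N=C/c1cccc(Br)c1`, 100 ug/mL
compound 3, `O=C(COc1cccc2ccccc12)N/N=C/c1ccc(F)cc1`, 100 ug/mL

Compound 3 stands level with compounds 1 and 2 in this assay; its nearest neighbour by value is compound 1, with no change at the digits printed from compound 1 to compound 3 (within the scatter), and its furthest is compound 2, with no change at the digits printed from compound 2 to compound 3 (within the scatter). Compound 4, `COc1ccc(/C=N/NC(=O)COc2cccc3ccccc23)cc1`, differs from compound 3 in one place: methoxy in place of fluoro on an aromatic carbon. For the measured compounds named here, three measured steps bear on this change, all of them swaps of a small group on the ring that sits on a carbon with a double bond to nitrogen: no change at the digits printed from compound 1 to compound 2 (within the scatter), no change at the digits printed from compound 1 to compound 3 (within the scatter) and no change at the digits printed from compound 2 to compound 3 (within the scatter). None of them moved the minimum cytotoxic concentration beyond the scatter, so no step beyond the scatter is expected for methoxy in place of fluoro either. Compound 4 is therefore expected to give about 100 ug/mL in this assay, with a range from 50 ug/mL to 200 ug/mL. The estimated step of no change at the digits printed from compound 3 to compound 4 (within the scatter) is expected to stay within the scatter.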

Compound 4, minimum cytotoxic concentration: 20 ug/mL
For compound 4 the middle estimate is 5.0-fold (0.70 log units) above the measured one; the measured number lies below the stated range.
By their numbers in this assay, from the lowest: compound 4; then compounds 1, 2 and 3 (each within the scatter of the next).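

In this assay, for the compounds shown here, compound 4 is the first of this series to leave the scatter, with a 5.0-fold lower number from compound 3 to compound 4 (0.70 log units; beyond the scatter), a 5.0-fold lower number from compound 1 to compound 4 (0.70 log units; beyond the scatter) and a 5.0-fold lower number from compound 2 to compound 4 (0.70 log units; beyond the scatter). The ring therefore does not accept every small group equally: hydrogen, the 3-bromophenyl of compound 2 and the 4-fluorophenyl of compound 3 all gave level numbers, whereas 4-methoxyphenyl lowered the concentration tolerated by the cells. Nothing available explains why methoxy differs from fluoro here.

As far as these compounds go, it remains open whether this drop is specific to methoxy or would also occur with other groups at the same place, such as hydroxy, ethoxy or an amine. From the compounds shown here alone, it is also open whether methoxy would lower the number in the same way at another place on the ring.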